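Swapping fluoro for chloro on a weak quinazoline-type inhibitor

The compounds below may be only part of what the source reports. "The series", "measured", "known", "first", "only" and "open" are said of these compounds alone.

Of the compounds shown here, three have been measured in a functional assay on MCF7 cells (Homo sapiens) for cytotoxicity, read by MTT assay, with a stated time of 48 h; a lower number here means a stronger inhibitor, a higher number a weaker inhibitor. Compound 1 `Fc1ccc2nc(-c3ccccc3)nc(Nc3ccccc3)c2c1` reaches only the limit of the assay, > 50000 nM. Compound 2 `COc1ccccc1Nc1nc(-c2cccc(F)c2)nc2ccc(F)cc12` likewise gives only the limit, > 50000 nM. For the measured compounds named here, compound 3 `Fc1cccc(Nc2nc(-c3cccc(F)c3)nc3ccc(F)cc23)c1` is the one compound that yields a number rather than a limit, 48700 nM in this assay, which places it just inside the range the assay can report; the move an at least 1.0-fold lower number from compound 2 to compound 3 (0.01 log units; that floor lies within the scatter) is too small to read as a change. The the limit of > 50000 nM in this assay, at which 2 of the 3 values shown sit, sets the frame for everything seen so far.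

Compound 4 `Fc1cccc(-c2nc(Nc3cccc(Cl)c3)c3cc(F)ccc3n2)c1` differs from compound 3 by chloro in place of fluoro on an aromatic carbon, on an aromatic carbon of a six-membered aromatic ring of carbon only. Going by the values given here, no measured step covers this exchange; the one step in hand, an at least 1.0-fold lower number from compound 2 to compound 3 (0.01 log units; that floor lies within the scatter), is a change at the same nitrogen and lies within the scatter. Compound 4 is therefore expected to sit near compound 3, with a step of a 1.1-fold lower number from compound 3 to compound 4 (0.03 log units; within the scatter), that is no change beyond the scatter. The estimate for compound 4 in this assay is 45000 nM, between 20000 nM and 100000 nM, and the value may well come back only as a limit.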

Compound 4, half-maximal inhibitory concentration: > 50000 nM
Compound 4: only a limit was reported; the forecaster's own chance of this, stated with the estimate: 55%; middle value at least 1.1-fold (0.04 log units) away from the limit.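

In this assay, exchanging fluoro for chloro, which turns the 3-fluorophenyl on the nitrogen into 3-chlorophenyl, gives an at least 1.0-fold higher number from compound 3 to compound 4 (0.01 log units; that floor lies within the scatter) and so shows no change at this position that can be told from the scatter. Compound 4 gives only a limit, not a number (> 50000 nM). The step from compound 2 to compound 4 cannot be read, and the results for this set remain framed by one feature: the limit of > 50000 nM in this assay, at which 3 of the 4 values shown sit.

Going by these compounds, what an amine or a carboxylic acid at this place on the ring would do remains open. On these data alone, it is equally open whether a longer chain there would return a number rather than a limit.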